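Replacing a hydroxycarbamoyl chain with a benzyl group

The source may hold more compounds than are shown below. What is called first, only, known or untested is meant among the compounds shown, and "the series" means these compounds.

Measured so far in a functional assay on A549 cells (Homo sapiens) for inhibition, read by sulforhodamine B assay, with a stated time of 48 h; on this read-out lower numbers stand for stronger inhibition and higher numbers for weaker inhibition:
Compound 1 `O=C(Nc1ccc(Nc2ncc(C(=O)NO)cn2)cc1)Nc1ccc(Cl)c(C(F)(F)F)c1` gives > 10000 nM, a limit.
Compound 2 `O=C(CCCCC(=O)Nc1ccc(NC(=O)Nc2ccc(Cl)c(C(F)(F)F)c2)cc1)NO` gives > 10000 nM, a limit.
Compound 3 `O=C(CCCCCCC(=O)Nc1ccc(NC(=O)Nc2ccc(Cl)c(C(F)(F)F)c2)cc1)NO` gives 9500 nM, a number.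

Compound 2 has no number of its own, and it stands on (the limit of > 10000 nM in this assay, at which 2 of the 3 values shown sit). Compound 4 `O=C(Nc1ccc(NCc2ccc(C(=O)NO)cc2)cc1)Nc1ccc(Cl)c(C(F)(F)F)c1` is the next to be read against it. It carries 4-(hydroxycarbamoyl)benzyl in place of (4-(hydroxycarbamoyl)butyl)carbonyl on a nitrogen on an aromatic ring.

Within the data shown here, two measured steps bear on this change. The earlier change on that nitrogen gave a step that the two limits leave unreadable from compound 1 to compound 2, so it fixes no size. Putting 2-(hydroxycarbamoyl)ethyl in place of hydroxycarbamoyl on the chain gave an at least 1.0-fold lower number from compound 2 to compound 3 (0.02 log units; that floor lies within the scatter), which stays within the scatter. Among the measured compounds shown here, neither step shows a large move, and compound 3 at 9500 nM is the only number to lean on. A large step in this assay is therefore not expected, and another limit for compound 4 would be no surprise. The step expected is small, an at least 1.4-fold lower number from compound 2 to compound 4 (0.15 log units; that floor lies within the scatter), with a slight lean towards a lower number. For compound 4 the estimated value is 7000 nM, with an expected range of 2000 nM to 20000 nM.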

Compound 4, half-maximal inhibitory concentration: 4300 nM
Compound 4: middle estimate off by 1.6-fold (0.21 log units), on the high side, within the range that was stated.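

In this assay, a change on the nitrogen on an aromatic ring now has a readable direction: 4-(hydroxycarbamoyl)benzyl in place of (4-(hydroxycarbamoyl)butyl)carbonyl gives an at least 2.3-fold lower number from compound 2 to compound 4 (0.36 log units; beyond the scatter), and 4-(hydroxycarbamoyl)benzyl in place of 5-(hydroxycarbamoyl)pyrimidin-2-yl gives an at least 2.3-fold lower number from compound 1 to compound 4 (0.36 log units; beyond the scatter). The group on this nitrogen can therefore move the read-out beyond the scatter, which the earlier step on the same nitrogen, unreadable between its two limits, could not show. Both new steps are only floors and their full size stays unknown, as compound 1 and compound 2 each stand at a limit: the limit of > 10000 nM in this assay, at which 2 of the 4 values shown sit.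

The change brings in an aromatic ring and removes the carbonyl on the nitrogen in one move, so the compounds shown do not tell which of the two goes with the step. Also open, on these data alone, is how the read-out would respond to a carboxylic acid in place of the hydroxycarbamoyl group on the benzyl, or to a saturated chain ending in hydroxycarbamoyl joined to the nitrogen without a carbonyl.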